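Series notes: pyridinylmethoxy to thiazolylmethoxy step

The source may report more compounds than this note shows. Statements on the series, on what has been measured and on what is new or still open speak of the compounds shown alone.

Measured in a functional assay on HEK293 cells for positive allosteric modulation of metabotropic glutamate receptor 5 (Homo sapiens), read by FLIPR and calcium flux; on this read-out higher numbers stand for an effect only at larger amounts of compound and lower numbers for an effect already at smaller amounts:
compound 1 `O=C(COCc1ccccc1)N1CCN(c2cccc(Cl)c2)CC1` gives 6700 nM
compound 2 `O=C(COCc1ccncc1)N1CCN(c2ccc(Cl)cc2F)CC1` gives 600 nM
compound 3 `O=C(COCc1cccnc1)N1CCN(c2ccc(Cl)cc2Cl)CC1` gives 1090 nM

The three measured compounds share one core and differ in the substitution of the aryl ring on the core and in the heteroaryl group on the methoxy arm. On the numbers shown, compound 3 has the second highest value of the three. Its nearest neighbour is compound 2, and that gap lies within the usual scatter, so no order between compound 2 and compound 3 can be read from these two numbers. Compound 1 lies furthest from compound 3, with the higher number, and that gap is beyond the scatter.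

Compound 4 `O=C(COCc1nccs1)N1CCN(c2ccc(Cl)cc2Cl)CC1` has not been measured. It differs from compound 3 in one place: 1,3-thiazol-2-yl in place of pyridin-3-yl on a saturated chain carbon bound to an oxygen on a saturated carbon. For the measured compounds named here, no measured pair in this set separates these two heteroaryl groups, so nothing in the data shows the direction of this change. With no such comparison available, the expected step from compound 3 to compound 4 in this assay is one that stays within the scatter, with no direction claimed; the expected step is a 1.1-fold higher number from compound 3 to compound 4 (0.04 log units; within the scatter). Compound 4 is therefore expected to give about 1200 nM in this assay, with a likely range from 400 nM to 3600 nM.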

Compound 4, half-maximal effective concentration: 10300 nM
For compound 4 the middle estimate is 8.6-fold (0.93 log units) below the measured one, and the stated range ends below it.
By their numbers in this assay, from the lowest: compounds 2 and 3 (each within the scatter of the next); then compounds 1 and 4 (each within the scatter of the next).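

In this assay, for the compounds shown here, 1,3-thiazol-2-yl in place of pyridin-3-yl gives a 9.4-fold higher number from compound 3 to compound 4 (0.98 log units; beyond the scatter), and this is the first pair that differs only at this position on the methoxy arm. Compounds 1, 2 and 3 differ from one another in more than one place, so they could not show that the heteroaryl group at this position alone can move the read-out beyond the scatter. Nothing available explains this step.

Going by these compounds alone, the single pair does not separate what changes together here, a six-membered aromatic ring with 1 hetero atom giving way to a five-membered aromatic ring with 2 hetero atoms, and a comparison with 1,3-oxazol-2-yl or 1,3-thiazol-4-yl on the same arm would help to tell whether the sulfur, the ring size or the point of attachment carries the step. On these data alone, it also remains open whether the step keeps its direction and size with the aryl substitution of compound 2 on the core, or with pyridin-2-yl as the reference group.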